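Cyano for lactam on a shared core: cytotoxicity outlook

The source may hold more compounds than are shown below. What is called first, only, known or untested is meant among the compounds shown, and "the series" means these compounds.

Measured compounds:
compound 1, `Cc1cc(-c2ccsc2)cn2c(CSCc3ccccc3)cnc12`, 9.4 ug/mL
compound 2, `Cc1cc(N2CCCC2=O)c2ncc(CSCCc3ccccc3)n2c1`, 25 ug/mL

The two measured compounds were tested in an ADME assay on HEL cells (Homo sapiens) for cytotoxicity, with a stated time of 3 days; on this read-out lower numbers stand for higher toxicity in this test and higher numbers for lower toxicity in this test. Compound 1 gives 9.4 ug/mL in this assay. Compound 2 gives 25 ug/mL in this assay, the higher of the two numbers, and the gap between the two values lies beyond the scatter of repeated measurements.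

Compound 3, `Cc1cc(C#N)c2ncc(CSCCc3ccccc3)n2c1`, is not yet measured in this assay. It differs from compound 2 in one place: cyano in place of 2-oxopyrrolidin-1-yl on an aromatic carbon. The side chain and the methyl group of compound 2 are kept.

Going by the values given here, no measured pair in this set shows the effect of such a change, so the expectation rests on compound 2 alone. Compound 3 is expected to give a value near that of compound 2, with no step beyond the scatter, perhaps leaning toward a somewhat lower number; the expected step is a 1.4-fold lower number from compound 2 to compound 3 (0.14 log units; within the scatter). Compound 3 is therefore estimated at 18 ug/mL in this assay, with a likely range from 7 ug/mL to 45 ug/mL.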

Compound 3, half-maximal cytotoxic concentration: > 100 ug/mL
Compound 3: no number, only a limit (the forecaster's own chance of this, stated with the estimate: 5%); at least 5.5-fold (0.74 log units) between middle value and limit.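

Replacing 2-oxopyrrolidin-1-yl with cyano on this aromatic carbon, with the side chain and the methyl group kept, gives an at least 4.0-fold higher number from compound 2 to compound 3 (0.60 log units; beyond the scatter) in this assay. Going by these compounds alone, this is the first direct sign that the group at this position bears on the read-out, which compound 1 and compound 2 could not show, as they differ in more than one place. Compound 3 has no number here, only a limit, so the true size of the step remains unknown: the limit of > 100 ug/mL in this assay, at which 1 of the 3 values shown sits.

A single pair cannot show which part of the exchange goes with the step: the loss of the five-membered ring, the smaller number of heavy atoms, or the cyano group itself. Also open, as far as these compounds go, is how an amine or a carboxylic acid on this aromatic carbon would read, and whether the same exchange would give a step of similar direction with a longer chain in place of the present side chain.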